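From Ethyl to Allyl: Expecting Paw Edema Inhibition

The source may hold more compounds than are shown below. What is called first, only, known or untested is meant among the compounds shown, and "the series" means these compounds.

The three measured compounds, all tested in a functional assay on the whole organism (strain albino) for inhibition, with Rattus norvegicus as the target, read by paw edema, with a stated time of 2 h, at a dose of 0.28 mmol/kg by the oral route (on this read-out lower numbers stand for less inhibition and higher numbers for more inhibition at the one dose given (going by the name of the read-out)), are these:

compound 1 `CCn1c(SCC(=O)c2ccccc2)nnc1-c1ccc(OC)cc1` gives 60%
compound 2 `COc1ccc(-c2nnc(SCC(=O)c3ccccc3)n2-c2ccccc2)cc1OC` gives 57%
compound 3 `CCn1c(SCC(=O)c2ccccc2)nnc1-c1ccccc1` gives 55%

Compound 1 has the highest of the three numbers, but its lead is small: compound 2 sits closest, and compound 3 furthest, both within the scatter of repeated measurements. Going by the values given here, the one step between compounds that differ in a single place is a number 5 percentage points lower from compound 1 to compound 3 (within the scatter), and it is within the scatter.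

Compound 4 `C=CCn1c(SCC(=O)c2ccccc2)nnc1-c1ccc(OC)cc1` differs from compound 1 by vinyl in place of methyl on a saturated chain carbon bound to an aromatic nitrogen; cut one bond further out, the same change reads ethyl to allyl. Among the compounds with values here, no measured step touches this saturated chain carbon bound to an aromatic nitrogen, so the only guide is that, within the shared core, the one change so far made at the aromatic carbon left the number within the scatter, as compound 3 shows with 55%. Compound 4 is therefore expected to land close to compound 1, with a step of no change at the digits printed from compound 1 to compound 4 (within the scatter), estimated at 60% within 48% to 70%.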

Compound 4, a percentage reported as inhibition, in the whole organism at one dose (the size of the read-out at that dose, not a potency): 53%
Beside the measured number, compound 4's estimate is 7 percentage points above it, and the stated range covers the measured number.
By their numbers in this assay, from the lowest: compounds 4, 3, 2 and 1 (each within the scatter of the next).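

Going by these compounds alone, compound 4 gives the first measured step at the saturated chain carbon bound to an aromatic nitrogen: in this assay, vinyl in place of methyl, which reads as ethyl to allyl, gives a number 7 percentage points lower from compound 1 to compound 4 (within the scatter) and so stays within the usual scatter. At this single dose, then, the added carbon and the double bond outside the aromatic rings do not separate the two compounds, so this position has now been probed as well as the aromatic carbon changed in compound 3. Nothing shown here gives a reason for this result.

The compounds shown leave open whether a larger change at this place would move the number beyond the scatter. Examples would be a longer chain such as butyl, or a chain ending in an amine or a carboxylic acid.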